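A few compounds are considered here, and "the series" means these few. Any claim that something is new, unique, unknown or untested is made for them only; others in the source may bear on it.

Among the measured compounds shown here, compound 3 `N#Cc1ccc2nc(-c3ccccn3)c(Nc3ccc(F)cc3)n2c1` is one of three compounds measured in an ADME assay on THP-1 cells (Homo sapiens) for cytotoxicity; a lower number here means that less compound is tolerated, a higher number that more compound is tolerated. For compound 3 the read-out is a limit of the assay, > 50000 nM. Compound 1 `CN(C)CCNc1c(-c2ccccn2)nc2ccccn12` likewise reaches only a limit, > 50000 nM. Compound 2 `COc1ccn2c(Nc3ccccc3F)c(-c3ccccn3)nc2c1` gives a number, 5750 nM. Compound 3 therefore stands at the limit of > 50000 nM in this assay, at which 2 of the 3 values shown sit. Compound 4 `COc1ccc2nc(-c3ccccn3)c(Nc3ccc(F)cc3)n2c1` differs from compound 3 by methoxy in place of cyano on an aromatic carbon. For the measured compounds named here, no measured pair of compounds shows this change, so its effect is not known from the data. The step of an at least 1.1-fold lower number from compound 3 to compound 4 (0.04 log units; that floor lies within the scatter) is expected to be none beyond the usual scatter. The estimate for compound 4 in this assay is 45000 nM, with a range from 15000 nM to 100000 nM.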

Compound 4, half-maximal cytotoxic concentration: 4260 nM
The estimate for compound 4 lay 11-fold (1.02 log units) above the measured number, and the stated range ends above it.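

Methoxy in place of cyano on this aromatic carbon gives, in this assay, an at least 11-fold lower number from compound 3 to compound 4 (1.06 log units; beyond the scatter) and so less of compound 4 is tolerated. Among the compounds shown here, no earlier pair showed that a swap at this one position, with both groups the same size in heavy atoms, can move the number beyond the scatter. The step is only a floor, because compound 3 gives a limit and not a number: the limit of > 50000 nM in this assay, at which 2 of the 4 values shown sit.

Going by these compounds, its true size stays open. So does how an amine, a carboxylic acid or a longer chain such as ethoxy would behave at this position.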